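Removing the hydroxy from compound 2

The compounds below may be only part of what the source reports. "The series", "measured", "known", "first", "only" and "open" are said of these compounds alone.

In an ADME assay on microsomes from liver (Homo sapiens) for metabolic stability, using NADPH, with a stated time of 40 min, tested at 2 uM (a higher number here means that the compound lasts longer, a lower number that the compound disappears faster), compound 1 (`Fc1cc(Cl)c2[nH]cc(-c3ccc4ccccc4n3)c2c1`) gives 0.383 h as its half-life, and compound 3 (`Fc1cc(F)c2[nH]cc(-c3ccc4ccccc4n3)c2c1`) gives 0.45 h as its half-life. Compound 2 (`Cc1cccc2c(-c3ccc4c(O)cccc4n3)c[nH]c12`) gives 0.283 h in this assay and lies within the scatter of both, so the three cannot be ranked.

Compound 4 (`Cc1cccc2c(-c3ccc4ccccc4n3)c[nH]c12`) differs from compound 2 by hydrogen in place of hydroxy on an aromatic carbon of a six-membered aromatic ring of carbon only hydrogen in place of hydroxy on an aromatic carbon and is otherwise the same structure.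

Going by the values given here, no measured step removes a hydroxy, so the evidence is indirect. Among the compounds with values here, the only measured step is a 1.2-fold higher number from compound 1 to compound 3 (0.07 log units; within the scatter) for fluoro in place of chloro on an aromatic carbon, and it lies within the scatter. Compound 1 at 0.383 h carries no hydroxy, and neither does compound 3 at 0.45 h or compound 4. Nothing measured therefore points to a large step on losing the hydroxy, although the halogens of compound 1 and compound 3 leave the comparison imperfect.

The expected step is a 1.2-fold higher number from compound 2 to compound 4 (0.09 log units; within the scatter) and it should lean slightly towards a higher number without leaving the scatter. For compound 4 the estimated half-life is 0.35 h with an expected range from 0.18 h to 0.65 h in this assay.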

Compound 4, half-life: 0.35 h
Compound 4: the middle estimate sits on the measured number at the digits printed; the range from low to high includes it.
By their numbers in this assay, from the lowest: compounds 2, 4, 1 and 3 (each within the scatter of the next).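

Hydrogen in place of hydroxy on this aromatic carbon, ortho to a fused ring and meta to a fused ring, gives the first direct reading at this position: in this assay the step is a 1.2-fold higher number from compound 2 to compound 4 (0.09 log units; within the scatter). Going by these compounds alone, the only earlier step was a halogen exchange, a different change at a different place, so it said nothing about this position. Here the loss of the hydroxy, with its one oxygen, its hydrogen-bond donor and its hydrogen-bond acceptor, leaves the half-life within the scatter, and no further data bear on the reason for this result.

Still open, as far as these compounds go, is whether any other group on this aromatic carbon, such as an amine, a methoxy or a carboxylic acid, would give a step beyond the scatter in this assay. Also open, from the compounds shown here alone, is whether a hydroxy at this place would read the same alongside the halogens of compound 1 and compound 3 as it does alongside the methyl of compound 2.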